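The source may report more compounds than this note shows. Statements on the series, on what has been measured and on what is new or still open speak of the compounds shown alone.

The measured compounds so far:
compound 1, `CCCCCCOc1c(-c2cc(OC)c(OC)c(OC)c2)oc2ccccc2c1=O`, 29200 nM
compound 2, `CCN(CC)CCCOc1c(-c2cc(OC)c(OC)c(OC)c2)oc2ccccc2c1=O`, 13600 nM

In a functional assay on PC-3 cells (Homo sapiens) for antiproliferative activity, read by WST assay, with a stated time of 3 days (a lower number here means a stronger inhibitor, a higher number a weaker inhibitor), compound 1 gives 29200 nM, the highest of the two numbers, while compound 2 gives 13600 nM. Compound 3, `CCCN(CCC)CCCCOc1c(-c2cc(OC)c(OC)c(OC)c2)oc2ccccc2c1=O`, is the unmeasured compound. It differs from compound 1 in one place: dipropylamino in place of ethyl on a saturated chain carbon, four bonds along the chain from an oxygen on an aromatic ring. Going by the values given here, only one measured step bears on this change, the one in which an amine likewise enters the side chain that hangs from the oxygen on the aromatic ring, a 2.1-fold lower number from compound 1 to compound 2 (0.33 log units; beyond the scatter). Because that step was a 2.1-fold lower number from compound 1 to compound 2 (0.33 log units; beyond the scatter), and the change to compound 3 again brings a dialkylamino group onto the same chain, one bond further out, a step of about that size toward a lower number is expected, a 2.1-fold lower number from compound 1 to compound 3 (0.32 log units; beyond the scatter). Compound 3 is therefore estimated at 14000 nM, with a likely range from 5000 nM to 35000 nM.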

Compound 3, half-maximal inhibitory concentration: 11600 nM
Beside the measured number, compound 3's estimate is 1.2-fold (0.08 log units) above it; low and high end bracket the measured number.
By their numbers in this assay, from the lowest: compounds 3 and 2 (each within the scatter of the next); then compound 1.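

Bringing a dipropylamino group onto the chain gives a 2.5-fold lower number from compound 1 to compound 3 (0.40 log units; beyond the scatter) in this assay. A second amine-bearing chain therefore also moves the number down from that of compound 1, so the earlier drop no longer rests on a single amine. The two amines cannot be told apart, with (dipropylamino)methyl in place of diethylamino giving a 1.2-fold lower number from compound 2 to compound 3 (0.07 log units; within the scatter) and nothing measured here accounting for any of these results.

Still open, from the compounds shown here alone, is how a ring amine such as piperidine or morpholine, or a carboxylic acid, would behave on this chain. A longer chain carrying diethylamino is also unexplored among the compounds shown.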